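The compounds below may be only part of what the source reports. "The series", "measured", "known", "first", "only" and "open" are said of these compounds alone.

Of the compounds shown here, three have been measured so far in an ADME assay on BJ cells (Homo sapiens) for cytotoxicity, read by MTT assay, with a stated time of 72 h; on this read-out lower numbers stand for stronger inhibition and higher numbers for weaker inhibition. Compound 1 `COc1cccc(CNc2ncnc3c2ncn3C2CCCCO2)c1` gives only a limit of the assay, > 100000 nM. Compound 2 `COc1cc(CNc2ncnc3c2ncn3C2CCCCO2)cc(OC)c1` likewise gives only a limit, > 100000 nM. Compound 3 `COc1ccc(CNc2ncnc3c2ncn3C2CCCO2)cc1` also gives only a limit, > 100000 nM.

The change from compound 1 to compound 2 is methoxy in place of hydrogen on an aromatic carbon. The step it made, a step that the two limits leave unreadable from compound 1 to compound 2, cannot be read in size because of the limit of > 100000 nM in this assay, at which 3 of the 3 values shown sit. Compound 4 `COc1ccc(CNc2ncnc3c2ncn3C2CCCO2)cc1OC` has not yet been measured. It differs from compound 3 by methoxy in place of hydrogen on an aromatic carbon. This is the same kind of change as that from compound 1 to compound 2, but not the same: in compound 2 the new methoxy sits meta to a methoxy group, whereas in compound 4 it sits ortho to a methoxy group. The difference between the core of compound 1 and the core of compound 3 is not broken down here.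

For the measured compounds named here, for compound 4 the step from compound 3 is expected to be a step that the limit leaves unreadable from compound 3 to compound 4, resting on the fact that every value so far sits at the limit (the limit of > 100000 nM in this assay, at which 3 of the 3 values shown sit). Compound 4 is therefore estimated at 150000 nM, most likely reported again only as a limit.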

Compound 4, half-maximal inhibitory concentration: > 100000 nM
Compound 4 gave a limit, no number; the forecaster's own chance of this, stated with the estimate: 85%; the middle value does not contradict the limit.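

In this assay compound 4 gives only a limit, > 100000 nM. No step can be read in size between compound 3 and compound 4, because both sit at the same limit: the limit of > 100000 nM in this assay, at which 4 of the 4 values shown sit. The compounds shown leave open whether methoxy in place of hydrogen on an aromatic carbon changes the read-out at all, and at what concentration any of the four would show inhibition.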